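Replacing cyclopentyl with pyridin-4-yl: compound 3 to compound 4

The compounds below may be only part of what the source reports. "The series", "measured", "known", "first", "only" and "open" are said of these compounds alone.

Measured so far in a physicochemical assay for solubility, in phosphate buffer, with a stated time of 18 h; a lower number here means a less soluble compound, a higher number a more soluble compound:

- Compound 1 `CC(C)(C)c1nc(-c2ccc[nH]2)c2cc(C(N)=O)c(N)nc2n1`: 130000 nM
- Compound 2 `CC(C)Cc1ncc2c(N)c(C#N)c(N)nc2n1`: 268000 nM
- Compound 3 `CC(C)(C)c1nc(C2CCCC2)c2c(N)c(C#N)c(N)nc2n1`: < 1000 nM, a limit

Compound 3 has no exact number, and its result of < 1000 nM is a limit of the assay. The data set records (the limit of < 1000 nM in this assay, at which 1 of the 3 values shown sits). The other two compounds returned numbers, with compound 1 at 130000 nM and compound 2 at 268000 nM.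

Compound 4 `CC(C)(C)c1nc(-c2ccncc2)c2c(N)c(C#N)c(N)nc2n1` keeps the core of compound 3 and carries pyridin-4-yl in place of cyclopentyl on an aromatic carbon. Within the data shown here, no two measured compounds differ in one place only, so no measured step offers a direct guide to this change. The expectation therefore rests on the structural change alone and carries wide uncertainty.

In this assay an upward change is expected, and the estimated size is an at least 6.0-fold higher number from compound 3 to compound 4 (0.77 log units; beyond the scatter). That size is measured from a limit rather than from a number, and a second limit remains possible for the new compound. For compound 4 the estimated value is 6000 nM, with an expected range from 1000 nM to 40000 nM.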

Compound 4, solubility: 44000 nM
For compound 4 the middle estimate is 7.3-fold (0.87 log units) below the measured one; the measured number lies above the stated range.
By their numbers in this assay, from the lowest: compound 4; then compound 1; then compound 2. At a limit, below all of these: compound 3.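

In this assay, among these compounds, the exchange of cyclopentyl for pyridin-4-yl on an aromatic carbon of a six-membered aromatic ring with 2 nitrogen gives the first single-place step: an at least 44-fold higher number from compound 3 to compound 4 (1.64 log units; beyond the scatter). The change replaces a five-membered non-aromatic ring of carbon only with a six-membered aromatic ring with 1 hetero atom, so the ring type and the ring nitrogen change together, and this one step cannot separate them. The full size of the step cannot be read because compound 3 has only a limit: the limit of < 1000 nM in this assay, at which 1 of the 4 values shown sits.

The compounds shown leave open whether the ring nitrogen or the aromatic ring carries the change, a question on which a phenyl or a pyridin-3-yl group at this carbon would bear. Also open, from the compounds shown here alone, is how a saturated ring holding nitrogen, such as piperidin-4-yl, or a longer chain would read at this place, and compound 1 and compound 2 give no guide, as each differs from compound 4 in more than one place.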